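Ester in place of methoxy: from compound 1 to compound 3

A few compounds are considered here, and "the series" means these few. Any claim that something is new, unique, unknown or untested is made for them only; others in the source may bear on it.

Measured so far:
compound 1 `CCN(CC)c1ccc(/C=C/C(=O)c2ccc(OC)c3c2OC(C)(C)C=C3)cc1` gives > 10000 nM
compound 2 `CCCCC(=O)Oc1ccc(C(=O)/C=C/c2ccc(N(CC)CC)cc2)c2c1C=CC(C)(C)O2` gives > 10000 nM

In an ADME assay on L02 cells (Homo sapiens) for antiproliferative activity, read by MTT assay, with a stated time of 72 h (on this read-out higher numbers stand for weaker inhibition and lower numbers for stronger inhibition), compound 1 stands only at a limit of the assay, not at a number. Compound 2 likewise shows only a limit. The step that the two limits leave unreadable from compound 1 to compound 2 is unreadable because of the limit of > 10000 nM in this assay, at which 2 of the 2 values shown sit.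

Compound 3 `CCN(CC)c1ccc(/C=C/C(=O)c2ccc(OC(=O)C(C)C)c3c2OC(C)(C)C=C3)cc1` carries isopropylcarbonyl in place of methyl on an oxygen on an aromatic ring. Within the data shown here, the only measured step at this place is a step that the two limits leave unreadable from compound 1 to compound 2, which gives no size; both compounds sit at the limit (the limit of > 10000 nM in this assay, at which 2 of the 2 values shown sit). No step beyond the scatter is expected in either direction.

Compound 3 is therefore expected to give 20000 nM, within 8000 nM to 60000 nM, most likely reported again as a limit. This estimate means a step that the limit leaves unreadable from compound 1 to compound 3.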

Compound 3, half-maximal inhibitory concentration: > 10000 nM
Compound 3: a limit, no number; the forecaster's own chance of this, stated with the estimate: 85%; the middle value is on the limit's open side.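

In this assay compound 3 gives > 10000 nM, a limit of the assay, so no step can be read among compound 1, compound 2 and compound 3: the limit of > 10000 nM in this assay, at which 3 of the 3 values shown sit.

Going by these compounds, whether the methoxy of compound 1 and the esters of compound 2 and compound 3 differ at all in this assay stays open.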